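A few compounds are considered here, and "the series" means these few. Any claim that something is new, unique, unknown or untested is made for them only; others in the source may bear on it.

Compound 2 `O=C(O)C1C(C(=O)NCCCc2ccccc2)[C@H]2CC[C@@H]1O2` stands level with its neighbours in an ADME assay on MCF7 cells (Homo sapiens) for cytotoxicity, read by MTT assay, with a stated time of 72 h; a lower number here means a stronger inhibitor of growth, a higher number a weaker inhibitor of growth: compound 2 gives 10000 nM, compound 1 `CCCNC(=O)C1C(C(=O)O)[C@@H]2CC[C@H]1O2` gives 10000 nM and compound 3 `Cn1ccc2cc(CNC(=O)C3C(C(=O)O)[C@@H]4CC[C@H]3O4)ccc21` gives 10000 nM. Among the measured compounds shown here, the one step among them, no change at the digits printed from compound 1 to compound 2 (within the scatter), shows no change beyond the scatter. Compound 4 `O=C(O)CCCNC(=O)C1C(C(=O)O)[C@@H]2CC[C@H]1O2` differs from compound 2 by carboxy in place of phenyl on a saturated chain carbon, three bonds along the chain from an amide-type nitrogen. For the measured compounds named here, no measured step exchanges phenyl for carboxy at this place, so the only guide is that compound 1, compound 2 and compound 3 all sit at the same value. On that basis compound 4 is expected to show no change at the digits printed from compound 2 to compound 4 (within the scatter), no change beyond the scatter. The estimate for compound 4 in this assay is 10000 nM, within 5000 nM to 20000 nM.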

Compound 4, concentration for 50% growth inhibition: 10000 nM
Estimate against measurement, compound 4: no gap at the digits printed; measured number inside the range.
By their numbers in this assay, from the lowest: compounds 1, 2, 3 and 4 (each within the scatter of the next).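

In this assay, carboxy in place of phenyl gives no change at the digits printed from compound 2 to compound 4 (within the scatter), and carboxy in place of hydrogen gives no change at the digits printed from compound 1 to compound 4 (within the scatter). The earlier step compared only hydrogen and phenyl on a saturated chain carbon, three bonds along the chain from an amide-type nitrogen; carboxy now reads alike with both, so three different groups at this place leave the value unmoved. From the compounds shown here alone, whether an amine or a longer chain here would depart from that shared value stays open. Nothing given here offers an explanation for this flat result.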